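The compounds below may be only part of what the source reports. "The series", "measured", "known", "first", "only" and "open" are said of these compounds alone.

Working notes on the series. Compound 1, `CC(=O)OCCC(=O)O[C@H](CC=C(C)C)C1=CC(=O)c2c(O)ccc(O)c2C1=O`, in a functional assay on DU-145 cells (Homo sapiens) for cytotoxicity, read by MTT assay (a lower number here means a stronger inhibitor, a higher number a weaker inhibitor), gives 15700 nM. Compound 2, `CC(C)=CC[C@@H](OC[C@H](C)O)C1=CC(=O)c2c(O)ccc(O)c2C1=O`, in this assay gives 24500 nM, and the step of a 1.6-fold higher number from compound 1 to compound 2 (0.19 log units; within the scatter) does not move the number meaningfully. Compound 3, `CC(C)=CC[C@@H](OC(=O)CC(C)(O)c1ccccc1)C1=CC(=O)c2c(O)ccc(O)c2C1=O`, in this assay reaches only a limit of the assay, > 100000 nM. Compound 3 therefore stands at the weak end of the three numbers shown, sitting at the limit of > 100000 nM in this assay, at which 1 of the 3 values shown sits, and its true value is not known. Within the data shown here, the step of an at least 6.3-fold higher number from compound 1 to compound 3 (0.80 log units; beyond the scatter) is the one change among the measured pairs that moved the number beyond the scatter.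

Compound 4 is `CC(C)=CC[C@@H](OC(=O)C1CCCCO1)C1=CC(=O)c2c(O)ccc(O)c2C1=O`. It differs from compound 3 by oxan-2-yl in place of 2-hydroxy-2-phenylpropyl on a carbonyl carbon. The step that bears on this change is an at least 6.3-fold higher number from compound 1 to compound 3 (0.80 log units; beyond the scatter), since the 1-hydroxy-1-phenylethyl group on the carbonyl carbon of compound 3 is the group now leaving, and its arrival in place of acetoxymethyl was what pushed compound 3 past the limit. Among the measured compounds shown here, compound 4 puts an oxan-2-yl on that carbonyl carbon instead, so the expectation in this assay is a return toward the region of compound 1, a lower number than the limit of compound 3, though the oxan-2-yl has no measured counterpart here. The estimate for compound 4 is 30000 nM, between 10000 nM and 100000 nM, an expected step of an at least 3.3-fold lower number from compound 3 to compound 4 (0.52 log units; beyond the scatter).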

Compound 4, half-maximal inhibitory concentration: 24700 nM
The estimate for compound 4 lay 1.2-fold (0.08 log units) above the measured number; the measured number falls inside the stated range.
By their numbers in this assay, from the lowest: compounds 1, 2 and 4 (each within the scatter of the next). At a limit, above all of these: compound 3.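

In this assay, oxan-2-yl on this carbonyl carbon in place of 2-hydroxy-2-phenylpropyl gives an at least 4.0-fold lower number from compound 3 to compound 4 (0.60 log units; beyond the scatter), so a ring on this carbonyl carbon does not by itself carry the series out of measurable range, and an aromatic ring with a hydroxyl on the same chain remains the only case that does. Set against the open-chain groups, oxan-2-yl cannot be told apart from them: in place of 2-acetoxyethyl it gives a 1.6-fold higher number from compound 1 to compound 4 (0.20 log units; within the scatter), and as (oxan-2-yl)carbonyl in place of 2-hydroxypropyl on the oxygen it gives a 1.0-fold higher number from compound 2 to compound 4 (0.00 log units; within the scatter). Three quite different groups on this oxygen thus read alike, and compound 3 alone stays a limit and not a number: the limit of > 100000 nM in this assay, at which 1 of the 4 values shown sits.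

The compounds shown do not separate the phenyl ring from the hydroxyl within 2-hydroxy-2-phenylpropyl as the part tied to that limit. Also open, on these data alone, is how a benzyl group or an aminomethyl group on this carbonyl carbon would read, and whether any group here can move the number beyond the scatter toward lower values.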